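Notes on compound 4 as an extension of compound 2

This account rests on a few compounds, and the source may have more. Where it says the series, first, only, none or still open, it means among the compounds named here.

Of the compounds shown here, three with a shared core have been measured. Compound 1 `Cc1cc(C)cc(N2CCNC(=O)N2)c1` gives 12000 nM in an assay on RBL-1 cells for inhibition of Polyunsaturated fatty acid 5-lipoxygenase (Rattus norvegicus); a lower number here means a stronger inhibitor, a higher number a weaker inhibitor. Compound 2 `O=C1NCCN(c2ccccn2)N1` gives 26000 nM, and compound 3 `O=C1NCCN(c2nc3ccccc3s2)N1` gives 32000 nM. Compound 2 thus holds the second highest of the three numbers: compound 3 sits within the scatter of it, while compound 1 lies lower by a gap beyond the scatter. Compound 4 `O=C1NCCN(c2cccc(-c3cccs3)n2)N1` is not yet measured; it differs from compound 2 by thiophen-2-yl in place of hydrogen on an aromatic carbon. Going by the values given here, no step between measured compounds offers a direct guide to this change. The step from compound 2 to compound 4 is expected to be a 2.9-fold lower number from compound 2 to compound 4 (0.46 log units; beyond the scatter), a modest move toward a lower number. Compound 4 is therefore estimated at 9000 nM, with a range from 2500 nM to 35000 nM.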

Compound 4, half-maximal inhibitory concentration: 8200 nM
The estimate for compound 4 lay 1.1-fold (0.04 log units) above the measured number; the range from low to high includes it.
By their numbers in this assay, from the lowest: compounds 4 and 1 (each within the scatter of the next); then compounds 2 and 3 (each within the scatter of the next).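

In this assay, going by these compounds alone, the thiophen-2-yl group, in place of hydrogen on an aromatic carbon next to the ring nitrogen, gives a 3.2-fold lower number from compound 2 to compound 4 (0.50 log units; beyond the scatter) and provides the only single-place comparison so far. This position therefore accepts an added aromatic ring with a modest move toward a lower number. No measurement shown explains this step.

Going by these compounds, it remains open whether the step is specific to thiophen-2-yl or would also appear with phenyl, methyl or an amine on the same carbon. On these data alone, the effect of thiophen-2-yl on the other carbons of this ring also remains open.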